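Replacing 4-formylphenyl with naphthalen-2-yl in compound 3

A few compounds are considered here, and "the series" means these few. Any claim that something is new, unique, unknown or untested is made for them only; others in the source may bear on it.

Compound 3 `COc1cc2c(cc1OC)CN(S(=O)(=O)c1ccc(-n3cc(COc4ccc(C=O)cc4)nn3)cc1)CC2` is one of a small set of compounds sharing a common core that were tested in an ADME assay on Vero cells (Chlorocebus sabaeus) for cytotoxicity, with a stated time of 4 days; a higher number here means a weaker inhibitor, a lower number a stronger inhibitor. In this assay compound 3 gives > 50 ug/mL, which is a limit of the assay rather than a number. Compound 1 `Cc1ccccc1OCc1cn(-c2ccc(S(=O)(=O)N3CCc4ccccc4C3)cc2)nn1` gives > 50 ug/mL in this assay, also a limit. Compound 2 `Cc1ccc(OCc2cn(-c3ccc(S(=O)(=O)N4CCc5ccccc5C4)cc3)nn2)cc1` gives > 50 ug/mL in this assay, again a limit. Within the data shown here, the only step between measured compounds, a step that the two limits leave unreadable from compound 1 to compound 2, therefore cannot be read in size. Compound 4 `COc1cc2c(cc1OC)CN(S(=O)(=O)c1ccc(-n3cc(COc4ccc5ccccc5c4)nn3)cc1)CC2` differs from compound 3 by naphthalen-2-yl in place of 4-formylphenyl on an oxygen on a saturated carbon. Among the measured compounds shown here, no measured step bears directly on this change; all that the data offer is the limit of > 50 ug/mL in this assay, at which 3 of the 3 values shown sit. Because of the limit of > 50 ug/mL in this assay, at which 3 of the 3 values shown sit, no step beyond the scatter in this assay can be expected with any confidence, and the change is estimated as a number no higher from compound 3 to compound 4 (the limit leaves the size open), essentially no movement. Compound 4 is expected to give about 50 ug/mL in this assay, within a range from 25 ug/mL to 100 ug/mL, most likely reported again as a limit.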

Compound 4, half-maximal inhibitory concentration: > 50 ug/mL
Compound 4 gave a limit, no number; the forecaster's own chance of this, stated with the estimate: 75%; the middle value sits exactly at the limit.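

Compound 4 gives > 50 ug/mL in this assay, which is a limit of the assay and not a number. No step can be read between compound 3 and compound 4, since both sit at the same limit: the limit of > 50 ug/mL in this assay, at which 4 of the 4 values shown sit. The compounds shown leave open at what concentration any of them would harm these cells, and whether naphthalen-2-yl in place of 4-formylphenyl changes that concentration at all.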